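The source may report more compounds than this note shows. Statements on the series, on what has been measured and on what is new or still open speak of the compounds shown alone.

Compound 1 `Cc1cc(C(=O)O)ccc1CN1CCC[C@H](O[C@H](CO)c2ccccc2)[C@@H]1c1ccccc1` was tested in an assay on isolated protein for activation of cGMP-dependent protein kinase 1 (Homo sapiens), read by ADP-Glo, with stated times of 30 min and 2 h; a lower number here means that less compound is needed, a higher number that more compound is needed for the effect. In this assay compound 1 gives only a limit, > 200000 nM. Compound 3 `CC(=O)NS(=O)(=O)c1ccc(CN2CCC[C@H](O[C@H](CO)c3cc(Cl)cc(Cl)c3)[C@@H]2c2ccccc2)cc1` likewise reaches only a limit in this assay, > 200000 nM. Compound 2 `Cc1cc(C(=O)O)ccc1C(C)N1CCC[C@H](O[C@H](CO)c2cc(Cl)cc(Cl)c2)[C@@H]1c1ccccc1` has no reported result in this assay: "nd" (no result reported). Compound 2 therefore stands without a number, and the two other values are limits rather than numbers. Compound 4 `Cc1nc(C(=O)O)ccc1CN1CCC[C@H](O[C@H](CO)c2cc(Cl)cc(Cl)c2)[C@@H]1c1ccccc1` differs from compound 2 by a group of 11 heavy atoms (8 carbon, 1 nitrogen, 2 oxygen; one six-membered aromatic ring with 1 hetero atom) in place of a group of 12 heavy atoms (10 carbon, 2 oxygen; one six-membered aromatic ring of carbon only), on an amine nitrogen in a ring. Among the measured compounds shown here, no step between measured compounds is available, so the size of this change cannot be read from the data. A limit is expected for compound 4 as well, since compound 1 and compound 3 both sit at the limit of > 200000 nM in this assay, at which 2 of the 3 values shown sit. Compound 4 is estimated at 200000 nM, ranging from 50000 nM to 500000 nM.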

Compound 4, half-maximal effective concentration: 144000 nM
For compound 4 the middle estimate is 1.4-fold (0.14 log units) above the measured one; the range from low to high includes it.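

Compound 2 has no number to set against compound 4, so no step can be read between them. The compounds shown leave open what that change on the amine nitrogen alone does in this assay.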